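This account rests on a few compounds, and the source may have more. Where it says the series, first, only, none or still open, it means among the compounds named here.

Of the compounds shown here, two have so far been measured in a functional assay on OVCAR-4 cells (Homo sapiens) for inhibition, read by sulforhodamine B assay, with a stated time of 48 h; a higher number here means a weaker inhibitor of growth, a lower number a stronger inhibitor of growth. Compound 1 `N#C/C(=C\N1CCN(C(=O)c2ccco2)C1=S)C(=O)Nc1ccc(Cl)cc1` gives 25200 nM in this assay, and compound 2 `O=CN1CCN(c2ccc(Cl)cc2)C1=S` gives 17300 nM in this assay. Compound 2 carries the lower of the two numbers, yet its distance from compound 1 lies within the usual scatter of repeated measurements, so both are best read as similarly weak inhibitors of growth. The next compound, compound 3 `O=CN1CCN(c2ccc(Cl)c(Cl)c2)C1=S`, differs from compound 2 by one change only: chloro in place of hydrogen on an aromatic carbon, the new chloro sitting ortho to the chloro already present and meta to the group of 8 heavy atoms. Among the measured compounds shown here, no measured pair shares this change, so there is no measured step to lean on. The expectation is a modest gain in growth inhibition, estimated as the step of a 1.4-fold lower number from compound 2 to compound 3 (0.16 log units; within the scatter), which may not clearly exceed the scatter. Compound 3 is therefore estimated at 12000 nM in this assay, with a range from 5000 nM to 30000 nM.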

Compound 3, concentration for 50% growth inhibition: 18200 nM
Compound 3: middle estimate off by 1.5-fold (0.18 log units), on the low side, and the stated range covers the measured number.
By their numbers in this assay, from the lowest: compounds 2, 3 and 1 (each within the scatter of the next).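

In this assay, chloro in place of hydrogen on the aromatic carbon ortho to a chloro group and meta to the group of 8 heavy atoms gives a 1.1-fold higher number from compound 2 to compound 3 (0.02 log units; within the scatter) as its step. Among the compounds shown here, this is the first single change that can be read directly here, and it shows that growth inhibition by compound 2 and compound 3 cannot be told apart. At this position, then, a second chloro brings no measurable gain or loss, and no available evidence bears on this result.

On these data alone, whether a different group on this same carbon, such as a methoxy group, an amine or a carboxylic acid, would separate clearly from compound 2 remains open. As far as these compounds go, how chloro would behave on the other carbons of this ring also remains open.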